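Adding One Methyl to Two Related Amides

The compounds below may be only part of what the source reports. "The series", "measured", "known", "first", "only" and "open" are said of these compounds alone.

Four compounds are compared in a functional assay on L1210 cells (Mus musculus) for inhibition; on this read-out higher numbers stand for weaker inhibition and lower numbers for stronger inhibition. Compound 1 `CC(C)C(NC(=O)NO)C(=O)NC1CCCC1` and compound 2 `CC(C)C(NC(=O)n1nnc2ccccc21)C(=O)NC1CCCC1` differ in their cores, and the difference between the two cores is not broken down here. In this assay compound 1 reports only a limit of the assay, > 200000 nM. Compound 2 likewise reports only a limit of the assay, > 200000 nM. For the measured compounds named here, compound 3 `CCC(C)C(NC(=O)n1nnc2ccccc21)C(=O)NC1CCCC1` is the first of the set to give a number, 102000 nM.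

The change from compound 2 to compound 3 is a single one: methyl in place of hydrogen on a saturated chain carbon, three bonds along the chain from an amide-type nitrogen and a carbonyl carbon It produced an at least 1.9-fold lower number from compound 2 to compound 3 (0.29 log units; that floor lies within the scatter), a step whose floor does not exceed the ordinary spread of repeated measurements.

Compound 4 `CCC(C)C(NC(=O)NO)C(=O)NC1CCCC1` carries the same change set against compound 1: methyl in place of hydrogen on a saturated chain carbon, three bonds along the chain from an amide-type nitrogen and a carbonyl carbon The place of the change is the same in both pairs, word for word, so this is the same change made on a second core.

Compound 1 sits at the limit of > 200000 nM in this assay, at which 2 of the 3 values shown sit. Going by the values given here, because the only measured example of this change gave an at least 1.9-fold lower number from compound 2 to compound 3 (0.29 log units; that floor lies within the scatter), a similar movement from compound 1 to compound 4 is expected, namely an at least 1.3-fold lower number from compound 1 to compound 4 (0.12 log units; that floor lies within the scatter). Since compound 1 itself begins at a limit, such a step may still leave compound 4 near or at that limit. Compound 4 is therefore estimated to come in at about 150000 nM, with a likely range from 70000 nM to 300000 nM, and a substantial chance that the assay again reports only a limit.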

Compound 4, half-maximal inhibitory concentration: > 100000 nM
Compound 4 was reported as a limit; the forecaster's own chance of this, stated with the estimate: 50%; the middle value is on the limit's open side.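

In this assay compound 4 gives > 100000 nM, which is a limit of the assay and not a number. For the compounds shown here, compound 1 also stands at a limit, > 200000 nM, so no step from compound 1 to compound 4 can be read. The compounds shown leave open whether the change from isopropyl to sec-butyl moves the number at all on the core of compound 1.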